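The compounds below may be only part of what the source reports. "The series", "measured", "known", "first", "only" and "open" are said of these compounds alone.

Measured so far:
- compound 1, `Cc1noc(NS(=O)(=O)c2ccc(NCc3ccccc3)cc2)c1C`: 9800 nM
- compound 2, `CCCCCNc1cccc2c(S(=O)(=O)Nc3onc(C)c3C)cccc12`: 80 nM
- compound 3, `Cc1noc(NS(=O)(=O)c2cccc3c(N(C)C)cccc23)c1Cc1ccccc1`: 50000 nM

Across the three numbers in an assay on VSM-A10 cells for antagonist activity at Endothelin-1 receptor (Rattus norvegicus) (on this read-out higher numbers stand for weaker inhibition and lower numbers for stronger inhibition), compound 2 gives the lowest, and each of its gaps to the others is beyond the scatter: compound 1 is the nearer of the two, compound 3 the further. Compound 2 is therefore the most potent of the measured set. Within the data shown here, no pair of measured compounds differs in only one place, so no single-change step is available; the gaps between compound 2 and the other two simply reflect several changes at once.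

Compound 4, `Cc1noc(NS(=O)(=O)c2cccc3c(NC(C)C)cccc23)c1C`, is not yet measured. It differs from compound 2 in one place: isopropyl in place of pentyl on a nitrogen on an aromatic ring. Nothing measured here isolates what that change does. As compound 2 carries the pentylamino group and sets the low end of the series in this assay at 80 nM, the working expectation is that moving to isopropylamino costs some potency, by an amount beyond the scatter but not large. The step from compound 2 to compound 4 is estimated at a 5.0-fold higher number from compound 2 to compound 4 (0.70 log units; beyond the scatter). Compound 4 is accordingly estimated at 400 nM, with a range of 100 nM to 2000 nM.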

Compound 4, half-maximal inhibitory concentration: 20 nM
The estimate for compound 4 lay 20-fold (1.30 log units) above the measured number; measured number below the stated range.
By their numbers in this assay, from the lowest: compound 4; then compound 2; then compound 1; then compound 3.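

In this assay, this nitrogen gives the series its first readable single change: a 4.0-fold lower number from compound 2 to compound 4 (0.60 log units; beyond the scatter) with isopropyl in place of pentyl on a nitrogen on an aromatic ring, a modest step beyond the scatter. The pentyl group is therefore not needed for the low numbers seen so far, and the group with 3 heavy atoms goes with stronger inhibition than the group with 5 heavy atoms on the shared core. No measurement shown bears on why the step runs in this direction.

A single pair cannot show whether inhibition follows the number of carbons, the shape of the group, or neither, and groups such as ethyl, cyclopropyl or a longer chain such as heptyl on the same nitrogen would separate these readings. As far as these compounds go, whether the step would carry over to the cores of compound 1 and compound 3 also stays open, as each differs from compound 2 and compound 4 in more than one place.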